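A few compounds are considered here, and "the series" means these few. Any claim that something is new, unique, unknown or untested is made for them only; others in the source may bear on it.

Among the measured compounds shown here, compound 2 `Cc1c(CN2CCCC2)cc(-c2ccc(Cl)cc2)n1Nc1ccnc2cc(Cl)ccc12` stands highest of the two numbers so far in a physicochemical assay for lipophilicity, measured as octanol-water partition (on this read-out higher numbers stand for higher lipophilicity and lower numbers for lower lipophilicity), at 5.17. For the measured compounds named here, its nearest neighbour is compound 1 `Cc1c(CN2CCCC2)cc(-c2ccccc2)n1Nc1ccnc2cc(Cl)ccc12`, which in this assay gives 4.6; the single step between them, a number 0.57 log units higher from compound 1 to compound 2 (beyond the scatter), came from putting chloro in place of hydrogen on an aromatic carbon. The next compound is compound 3 `Cc1c(CN2CCCC2)cc(-c2ccc(F)cc2)n1Nc1ccnc2cc(Cl)ccc12`. It differs from compound 2 by fluoro in place of chloro on an aromatic carbon, that is, 4-chlorophenyl to 4-fluorophenyl. Going by the values given here, no measured step swaps one halogen for another here; the only step bearing on it is the one from compound 1 to compound 2, which showed what a chloro on this ring is worth against hydrogen. A fluoro is expected to give back part of that gain, so the expected step is a number 0.42 log units lower from compound 2 to compound 3 (beyond the scatter) in this assay. Compound 3 is therefore estimated at 4.75, with a range from 4.45 to 5.05.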

Compound 3, partition coefficient: 4.86
Estimate against measurement, compound 3: 0.11 log units below, and the stated range covers the measured number.
By their numbers in this assay, from the lowest: compounds 1 and 3 (each within the scatter of the next); then compound 2.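

In this assay the two halogens at this position now part ways, with the change from 4-chlorophenyl to 4-fluorophenyl giving a number 0.31 log units lower from compound 2 to compound 3 (beyond the scatter). Fluoro in place of hydrogen gives a number 0.26 log units higher from compound 1 to compound 3 (within the scatter), so on this ring, para to a large group, fluoro cannot be told apart from hydrogen, whereas chloro can, something the single chloro step could not show. Nothing available offers a reason for this difference between the two halogens.

The compounds shown carry only hydrogen, fluoro or chloro here, so it remains open where a methyl, a methoxy or a trifluoromethyl group would fall in this assay. As far as these compounds go, it also remains open whether these halogen steps would hold at another place on the same ring.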